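Swapping Chloro for Amino: Expected Effect on Cytotoxicity

The source may report more compounds than this note shows. Statements on the series, on what has been measured and on what is new or still open speak of the compounds shown alone.

Measured so far:
compound 1, `ClCc1cccc(Cn2cnc3c(Cl)nc(Cl)nc32)c1`: 6160 nM
compound 2, `Nc1nc(Cl)c2ncn(Cc3ccccc3CCl)c2n1`: 26300 nM
compound 3, `ClCc1cccc(Cn2cnc3nc(Cl)nc(Cl)c32)c1`: 5750 nM

These numbers come from a functional assay on HCC 2998 cells (Homo sapiens) for cytotoxicity, read by sulforhodamine B assay, with a stated time of 48 h; a higher number here means that more compound is tolerated, a lower number that less compound is tolerated. Compound 1 holds the second highest of the three values; compound 3 sits nearest, within the usual scatter, while compound 2 lies furthest away, beyond the scatter. Compound 4, `Nc1nc(Cl)c2ncn(Cc3cccc(CCl)c3)c2n1`, has not yet been tested in this assay. It differs from compound 1 in one place: amino in place of chloro on an aromatic carbon. Among the compounds with values here, no step between measured compounds shows this same change, so the expected size must rest on the values themselves. Because compound 2 gives 26300 nM and also carries an amino group, a moderate rise in the number is expected, a 2.4-fold higher number from compound 1 to compound 4 (0.39 log units; beyond the scatter). Compound 4 is accordingly estimated at 15000 nM, within a range from 6000 nM to 40000 nM.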

Compound 4, concentration lethal to 50% of the cells: 77600 nM
Estimate against measurement, compound 4: 5.2-fold (0.71 log units) below, outside the stated range (above it).
By their numbers in this assay, from the lowest: compounds 3 and 1 (each within the scatter of the next); then compound 2; then compound 4.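

In this assay amino in place of chloro on the aromatic carbon between two ring nitrogen atoms gives a 13-fold higher number from compound 1 to compound 4 (1.10 log units; beyond the scatter). Within the data shown here, this is the first step between compounds that differ in one place, and it shows that exchanging this one heavy atom is enough to move the number well beyond the scatter. No measurement shown here explains the size of this step. The compounds shown leave open whether a methylamino or a methoxy group on this same carbon would move the number as far, and what amino would do in place of the remaining chloro group.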